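Compound 3 alone gives a number, but its side chain may not carry over

The compounds below may be only part of what the source reports. "The series", "measured", "known", "first", "only" and "open" are said of these compounds alone.

Measured in a functional assay on DLD-1 cells (Homo sapiens) for antiproliferative activity, read by sulforhodamine B assay, with a stated time of 48 h; on this read-out lower numbers stand for stronger inhibition and higher numbers for weaker inhibition:
Compound 1 `CCCCN(C)C(=O)CCCOc1cc(OC)c(OC)c2oc(-c3ccc(OC)cc3)c(O)c(=O)c12`: > 40000 nM, a limit
Compound 2 `COc1ccc(-c2oc3c(OC)c(OC)cc(OCCCC(=O)N4CCN(C)CC4)c3c(=O)c2O)cc1`: > 40000 nM, a limit
Compound 3 `CCCCN(C)C(=O)CCCCOc1cc(OC)c(OC)c2oc(-c3ccc(OC)cc3)c(O)c(=O)c12`: 17400 nM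

Among the measured compounds shown here, compound 3 is the only one with an actual number, while the limit of > 40000 nM in this assay, at which 2 of the 3 values shown sit, covers the other two. Compound 4 `COc1ccc(-c2oc3c(OC)c(OC)cc(OC(C)CN(C)C)c3c(=O)c2O)cc1` is unmeasured. It carries 1-((dimethylamino)methyl)ethyl in place of 4-(butyl(methyl)carbamoyl)butyl on an oxygen on an aromatic ring. For the measured compounds named here, two measured steps bear on this, an at least 2.2-fold lower number from compound 1 to compound 3 (0.36 log units; beyond the scatter) and an at least 2.2-fold lower number from compound 2 to compound 3 (0.36 log units; beyond the scatter). In both, the longer chain gives the lower number, and the change here shortens the chain. Neither step tests the entering group. In this assay the expected step is modest, towards weaker inhibition: a 2.2-fold higher number from compound 3 to compound 4 (0.34 log units; beyond the scatter). The estimated value for compound 4 is 38000 nM, within an expected range of 12000 nM to 100000 nM.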

Compound 4, half-maximal inhibitory concentration: 2560 nM
For compound 4 the middle estimate is 15-fold (1.17 log units) above the measured one; measured number below the stated range.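

In this assay, the smaller 1-((dimethylamino)methyl)ethyl on the oxygen gives a 6.8-fold lower number from compound 3 to compound 4 (0.83 log units; beyond the scatter), so a longer chain is not what sets the lower number at this position. The same entering group also gives an at least 15-fold lower number from compound 2 to compound 4 (1.19 log units; beyond the scatter) and an at least 15-fold lower number from compound 1 to compound 4 (1.19 log units; beyond the scatter). Compound 1 and compound 2 have limits, not numbers, so these two steps have open ends: the limit of > 40000 nM in this assay, at which 2 of the 4 values shown sit.

This single change alters chain length, branching and the loss of the carbonyl together, and the compounds shown do not separate them. As far as these compounds go, how an unbranched 2-(dimethylamino)ethyl group or a pyrrolidine-bearing chain would read remains open.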